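Bromo for chloro on a shared aromatic ring

The source may hold more compounds than are shown below. What is called first, only, known or untested is meant among the compounds shown, and "the series" means these compounds.

Three closely related compounds have been measured in an ADME assay on L02 cells (Homo sapiens) for cytotoxicity, read by MTT assay, with a stated time of 24 h; on this read-out lower numbers stand for stronger inhibition and higher numbers for weaker inhibition. Compound 1 (`COc1cc(/C=C2\CN(C)C/C(=C\c3ccc(Br)cc3)C2=O)cc(OC)c1`) gives 21300 nM, compound 2 (`COc1cc(/C=C2\CN(C)C/C(=C\c3ccc(F)cc3)C2=O)cc(OC)c1OC`) gives 10700 nM and compound 3 (`COc1cc(/C=C2\CN(C)C/C(=C\c3ccc(Cl)cc3)C2=O)cc(OC)c1OC`) gives 14000 nM. Compound 3 holds the middle place among these three numbers, but its gaps to compound 2 and to compound 1 both lie within the scatter, so that place carries little weight.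

Compound 4 (`COc1cc(/C=C2\CN(C)C/C(=C\c3ccc(Br)cc3)C2=O)cc(OC)c1OC`) has not yet been measured. It differs from compound 3 by a single exchange, bromo in place of chloro on an aromatic carbon. Going by the values given here, the one measured step of the same kind is chloro in place of fluoro on an aromatic carbon, a 1.3-fold higher number from compound 2 to compound 3 (0.12 log units; within the scatter), and it stays within the scatter. Compound 1, at 21300 nM, also carries the bromo group, but it differs from compound 4 elsewhere as well and is only a loose guide. No step beyond the scatter is therefore expected in this assay. The expected change is a 1.1-fold higher number from compound 3 to compound 4 (0.04 log units; within the scatter), with no firm direction. For compound 4 the estimated value is 15500 nM, with an expected range from 8500 nM to 28000 nM.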

Compound 4, half-maximal inhibitory concentration: 15400 nM
Compound 4: the middle estimate sits 1.0-fold (0.00 log units) above what was measured; the range from low to high includes it.
By their numbers in this assay, from the lowest: compounds 2, 3, 4 and 1 (each within the scatter of the next).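

In this assay, the exchange of chloro for bromo on this six-membered aromatic ring stays within the scatter (a 1.1-fold higher number from compound 3 to compound 4 (0.04 log units; within the scatter)), and so does the wider exchange of fluoro for bromo (a 1.4-fold higher number from compound 2 to compound 4 (0.16 log units; within the scatter)), so fluoro, chloro and bromo at this place, para to a large group, cannot be told apart on these numbers. Going by these compounds alone, the bromo pair also gives the first reading of a change elsewhere in the molecule, methoxy in place of hydrogen on an aromatic carbon, and that step too lies within the scatter (a 1.4-fold lower number from compound 1 to compound 4 (0.14 log units; within the scatter)). Nothing available here bears on the reason for these small steps.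

Since only halogens stand at this place in the compounds shown, they leave open whether an amine or a carboxylic acid there would give a step beyond the scatter. From the compounds shown here alone, the methoxy step is also seen only alongside the 4-bromophenyl group, so whether it would stay as small alongside 4-chlorophenyl or a fluoro-bearing ring remains open.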